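Chain growth on the sulfonamide aryl: compound 2 to compound 4

This account rests on a few compounds, and the source may have more. Where it says the series, first, only, none or still open, it means among the compounds named here.

The shared core carries an aryl on the sulfonamide nitrogen. Compound 1 `Cc1cccc(NS(=O)(=O)c2ccc(N3CCNC3=O)cc2)c1` gives 190 nM in a functional assay on MCF7 cells (Homo sapiens) for antiproliferative activity, read by sulforhodamine B assay, with a stated time of 48 h (a higher number here means a weaker inhibitor, a lower number a stronger inhibitor), compound 3 `Cc1ccc(NS(=O)(=O)c2ccc(N3CCNC3=O)cc2)c(C)c1` gives 230 nM, and compound 2 `CCc1ccc(NS(=O)(=O)c2ccc(N3CCNC3=O)cc2)cc1` gives 810 nM, the highest of the three numbers: a 3.5-fold lower number from compound 2 to compound 3 (0.55 log units; beyond the scatter) and a 4.3-fold higher number from compound 1 to compound 2 (0.63 log units; beyond the scatter) both lie beyond the scatter. Compound 4 `CC(C)Cc1ccc(NS(=O)(=O)c2ccc(N3CCNC3=O)cc2)cc1` differs from compound 2 by isopropyl in place of methyl on a saturated chain carbon bound to an aromatic carbon. Going by the values given here, none of the measured steps alters a chain on the aryl; each swaps the substitution pattern of the ring itself, so no step bears directly on this change, and a 1.2-fold higher number from compound 1 to compound 3 (0.08 log units; within the scatter) shows only that the ring pattern can be altered without effect. For compound 4 the expected step is a 1.2-fold higher number from compound 2 to compound 4 (0.09 log units; within the scatter), not beyond the scatter. The estimate for compound 4 is 1000 nM, range 350 nM to 2800 nM.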

Compound 4, half-maximal inhibitory concentration: > 1000 nM
Compound 4: a limit, no number; the forecaster's own chance of this, stated with the estimate: 5%; the middle value sits exactly at the limit.
By their numbers in this assay, from the lowest: compounds 1 and 3 (each within the scatter of the next); then compound 2. At a limit, above all of these: compound 4.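

Compound 4 reads only as a limit in this assay: the limit of > 1000 nM in this assay, at which 1 of the 4 values shown sits.

Isopropyl in place of methyl on a saturated chain carbon bound to an aromatic carbon gives an at least 1.2-fold higher number from compound 2 to compound 4 (0.09 log units; that floor lies within the scatter), so only a floor for the step can be read. Going by these compounds alone, the earlier steps changed the ring pattern, whereas this is the first chain change at this place, and the limit shows no gain in inhibition from it.

On these data alone, the true size of the step stays open. So does the effect of an amine or a carboxylic acid in place of isopropyl.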